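The compounds below may be only part of what the source reports. "The series", "measured", "known", "first", "only" and "open" are said of these compounds alone.

In an assay on HEK293 cells for displacement of a labelled ligand from adenosine receptor A2b (Homo sapiens), read by scintillation counting, with a stated time of 30 min, tested at 10 uM (on this read-out lower numbers stand for less inhibition and higher numbers for more inhibition at the one concentration tested (going by the name of the read-out)), compound 1 `N=c1oc2ccc(Br)cc2cc1C(=O)NCCO` gives 15%. Compound 2 `N=c1oc2ccc(Br)cc2cc1C(=O)NC1CCCCC1` gives 10% in this assay, the lowest of the two numbers, with compound 1 nearest; the measured step of a number 5 percentage points lower from compound 1 to compound 2 (within the scatter) lies within the scatter. Compound 3 `CCC(CO)NC(=O)c1cc2cc(Br)ccc2oc1=N` differs from compound 2 by 1-(hydroxymethyl)propyl in place of cyclohexyl on an amide-type nitrogen. For the measured compounds named here, the only step bearing on this change, a number 5 percentage points lower from compound 1 to compound 2 (within the scatter), put cyclohexyl in place of 2-hydroxyethyl without moving the number beyond the scatter, and here 1-(hydroxymethyl)propyl replaces cyclohexyl again. The step is therefore expected to be a number 3 percentage points higher from compound 2 to compound 3 (within the scatter), nothing beyond the scatter. Compound 3 is expected to give 13%, between 3% and 25%.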

Compound 3, a percentage reported as inhibition, at one concentration (the size of the read-out at that concentration, not a potency): 4%
The estimate for compound 3 lay 9 percentage points above the measured number; the measured number falls inside the stated range.
By their numbers in this assay, from the lowest: compounds 3, 2 and 1 (each within the scatter of the next, the first and the last beyond it).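

In this assay, 1-(hydroxymethyl)propyl in place of cyclohexyl on an amide-type nitrogen gives a number 6 percentage points lower from compound 2 to compound 3 (within the scatter), so this swap, like the earlier one, does not separate the two groups. Ethyl in place of hydrogen on the saturated chain carbon bound to that nitrogen gives a number 11 percentage points lower from compound 1 to compound 3 (beyond the scatter), the first step here to pass the scatter, though only modestly. No evidence accounts for this step. From the compounds shown here alone, whether an amine or a carboxylic acid on this chain would change the number remains open.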